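The compounds below may be only part of what the source reports. "The series", "measured", "known", "first", "only" and "open" are said of these compounds alone.

Compound 1, `Nc1scc(-c2ccc(I)cc2)c1C(=O)c1ccccc1`: in a functional assay on CHO cells for agonist activity at adenosine receptor A1 (Homo sapiens), read by fluorescence and ERK phosphorylation, with stated times of 30 min and 1.5 h, tested at 3 uM (a higher number here means a stronger effect of the compound at the concentration tested, a lower number a weaker effect), compound 1 gives 51%.
Compound 2, `Nc1scc(-c2ccc([N+](=O)[O-])cc2)c1C(=O)c1ccccc1`: in this assay compound 2 gives 50%.
Compound 3, `Nc1scc(-c2ccc(I)cc2)c1C(=O)c1ccc(Cl)cc1`: in this assay compound 3 gives 54%.

The three measured compounds share one core and differ at two places. Compound 2 differs from compound 1 by nitro in place of iodo on an aromatic carbon; the step is a number 1 percentage points lower from compound 1 to compound 2 (within the scatter). Compound 3 differs from compound 1 by chloro in place of hydrogen on an aromatic carbon; the step is a number 3 percentage points higher from compound 1 to compound 3 (within the scatter). Compound 2 and compound 3 carry both changes relative to one another, and their two values lie close together.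

Compound 4, `Nc1scc(-c2ccc([N+](=O)[O-])cc2)c1C(=O)c1ccc(Cl)cc1`, has not yet been measured in this assay. It differs from compound 3 by nitro in place of iodo on an aromatic carbon, the same change as that from compound 1 to compound 2, at the same place. The step from compound 3 to compound 4 is expected to be a number 1 percentage points lower from compound 3 to compound 4 (within the scatter), because a number 1 percentage points lower from compound 1 to compound 2 (within the scatter) was a small step within the scatter and compound 3 starts from 54%. Compound 4 is therefore estimated at 53%, with a likely range from 43% to 63%.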

Compound 4, a percentage reported as activity, at one concentration (the size of the read-out at that concentration, not a potency): 47%
Beside the measured number, compound 4's estimate is 6 percentage points above it; the measured number falls inside the stated range.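

In this assay, nitro in place of iodo gives a number 7 percentage points lower from compound 3 to compound 4 (within the scatter), and this step stands beside the earlier one on the core of compound 1 with no difference that can be told from the scatter: the same change on two cores in this assay, a number 1 percentage points lower (within the scatter) from compound 1 to compound 2 and a number 7 percentage points lower (within the scatter) from compound 3 to compound 4, 6 percentage points apart, within the scatter of two such steps. Chloro in place of hydrogen gives a number 3 percentage points lower from compound 2 to compound 4 (within the scatter), and it reads the same way when set beside its earlier step: the same change on two cores in this assay, a number 3 percentage points higher (within the scatter) from compound 1 to compound 3 and a number 3 percentage points lower (within the scatter) from compound 2 to compound 4, 6 percentage points apart, within the scatter of two such steps. Both changes therefore carry across these two cores without a detectable difference, but all four steps lie within the scatter, so this does not show that either change has a real effect of its own, nor that the steps would stay alike on any further core.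

The compounds shown leave open how an amine or a carboxylic acid would read in the place of iodo, and how a methoxy group or a longer chain would read in the place of chloro. They also leave open whether the effects would compare the same way at another concentration: each read-out here gives the size of the effect at a single concentration.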